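Cyano added to the five-membered ring of compound 3

The compounds below may be only part of what the source reports. "The series", "measured", "known", "first", "only" and "open" are said of these compounds alone.

Compound 1 `CN(CCN(C)C(=O)n1cccn1)Cc1ccc(OCc2ccccc2)cc1` carries a single benzyloxy-substituted benzyl group on the diamine chain; in an assay on membranes from brain for binding affinity to Fatty-acid amide hydrolase 1 (Mus musculus), read by fluorescence, with stated times of 1 h and 30 min (on this read-out higher numbers stand for weaker inhibition and lower numbers for stronger inhibition), compound 1 gives 510 nM. Compound 2 `Cc1cnn(C(=O)N(C)CCN(C)C(c2ccc(OCc3ccccc3)cc2)c2ccc(OCc3ccccc3)cc2)c1` and compound 3 `CN(CCN(C)C(c1ccc(OCc2ccccc2)cc1)c1ccc(OCc2ccccc2)cc1)C(=O)n1cccn1` both carry two such aryl groups on one carbon. In this assay compound 2 reaches only the limit > 1000000 nM. In this assay compound 3 likewise reaches only the limit > 1000000 nM. Compound 3 therefore stands at a limit, not a number, and one further value shown is a limit as well (the limit of > 1000000 nM in this assay, at which 2 of the 3 values shown sit). The step that the two limits leave unreadable from compound 2 to compound 3 lies between two limits and has no readable size.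

Compound 4 `CN(CCN(C)C(c1ccc(OCc2ccccc2)cc1)c1ccc(OCc2ccccc2)cc1)C(=O)n1cc(C#N)cn1` differs from compound 3 by cyano in place of hydrogen on an aromatic carbon of the five-membered aromatic ring with 2 nitrogen. Among the compounds with values here, no measured step alters this ring carbon in a readable way; the only step there, from compound 2 to compound 3, sits between two limits. Both compounds carrying the two aryl groups on one carbon sit at the limit, and compound 4 keeps that feature, so the expectation is that compound 4 also sits at the limit. In this assay compound 4 is estimated at 1000000 nM, between 100000 nM and 10000000 nM. The expected step of a number no higher from compound 3 to compound 4 (the limit leaves the size open) is estimated as none beyond the scatter.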

Compound 4, half-maximal inhibitory concentration: > 1000000 nM
Compound 4 was reported as a limit (the forecaster's own chance of this, stated with the estimate: 85%); the middle value sits exactly at the limit.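

In this assay compound 4 gives only a limit, > 1000000 nM. No step among compound 2, compound 3 and compound 4 can be read, with all three sitting at the same limit: the limit of > 1000000 nM in this assay, at which 3 of the 4 values shown sit.

The compounds shown leave open whether cyano or methyl in place of hydrogen on the five-membered aromatic ring alters inhibition in a compound that gives a number, such as compound 1.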